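The source may hold more compounds than are shown below. What is called first, only, known or untested is meant among the compounds shown, and "the series" means these compounds.

Of the compounds shown here, three of a shared core have been tested in a functional assay on M21 cells (Homo sapiens) for antiproliferative activity, read by sulforhodamine B assay, with a stated time of 48 h; a lower number here means a stronger inhibitor, a higher number a weaker inhibitor. Compound 1 `CC(C)c1ccccc1OS(=O)(=O)c1cccc(NC(=O)CCCl)c1` gives > 40000 nM in this assay, which is a limit of the assay and not a number (the limit of > 40000 nM in this assay, at which 1 of the 3 values shown sits). Compound 2 `CCC(=O)Nc1ccc(S(=O)(=O)Oc2ccccc2C(C)C)cc1` gives 11000 nM in this assay. Compound 3 `CCC(=O)Nc1ccc(S(=O)(=O)Oc2ccccc2I)cc1` gives 11000 nM in this assay, level with compound 2. Among the compounds with values here, the one measured step, no change at the digits printed from compound 2 to compound 3 (within the scatter), reads as no change within the scatter. Compound 4 `CCCCCC(=O)Nc1ccc(S(=O)(=O)Oc2ccccc2I)cc1` has not yet been measured; it differs from compound 3 by propyl in place of hydrogen on a saturated chain carbon, two bonds along the chain from a carbonyl carbon. Within the data shown here, that measured step exchanged a group on an aromatic carbon and left the acyl chain untouched, so it does not bear directly on the change to compound 4, and no other step is available. The expectation for this assay is therefore a step no larger than the scatter, in no fixed direction. Compound 4 is expected to give about 11000 nM in this assay, with a range from 3000 nM to 40000 nM. This estimate means an expected step of no change at the digits printed from compound 3 to compound 4 (within the scatter).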

Compound 4, half-maximal inhibitory concentration: 11000 nM
Compound 4: middle estimate and measured number agree at the digits printed, within the range that was stated.
By their numbers in this assay, from the lowest: compounds 2, 3 and 4 (each within the scatter of the next). At a limit, above all of these: compound 1.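

In this assay the acyl chain now has a step of its own: with the iodo group held in place, the change of propanoyl to pentylcarbonyl gives no change at the digits printed from compound 3 to compound 4 (within the scatter). This position, two bonds along the chain from a carbonyl carbon, therefore takes a propyl group in place of hydrogen with no shift beyond the scatter, which the earlier step on an aromatic carbon could not show. No measurement given here speaks to why this step reads as it does.

The compounds shown leave open whether a longer chain, or an amine or a carboxylic acid at the end of this chain, would read differently in this assay. They also leave open whether the same propyl change would read alike with isopropyl on the aromatic carbon.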